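Pyridin-2-yl for isopropyl on a ring amine nitrogen

The source may hold more compounds than are shown below. What is called first, only, known or untested is meant among the compounds shown, and "the series" means these compounds.

In a functional assay on CCRF-CEM cells for antagonist activity at C-X-C chemokine receptor type 4 (Homo sapiens), read by calcium flux, with stated times of 25 min and 90 s (on this read-out higher numbers stand for weaker inhibition and lower numbers for stronger inhibition), compound 1 `CC(C)N1CCN(c2cccc3c2C[C@H](CN(C)[C@H]2CCCc4cccnc42)NC3)CC1` gives 16.9 nM, the second highest of the three numbers measured. Compound 2 `C[C@@H]1CN(c2cccc3c2C[C@H](CN(C)[C@H]2CCCc4cccnc42)NC3)C[C@H](C)N1C` gives 14.1 nM and compound 3 `CN(C[C@H]1Cc2c(cccc2N2C[C@H]3C[C@@H]2CN3)CN1)[C@H]1CCCc2cccnc21` gives 20.7 nM; the steps of a 1.2-fold lower number from compound 1 to compound 2 (0.08 log units; within the scatter) and a 1.2-fold higher number from compound 1 to compound 3 (0.09 log units; within the scatter) both stay within the scatter. Compound 4 `CN(C[C@H]1Cc2c(cccc2N2CCN(c3ccccn3)CC2)CN1)[C@H]1CCCc2cccnc21` differs from compound 1 by pyridin-2-yl in place of isopropyl on an amine nitrogen in a ring. Among the measured compounds shown here, no measured step touches this position: a 1.2-fold lower number from compound 1 to compound 2 (0.08 log units; within the scatter), a 1.2-fold higher number from compound 1 to compound 3 (0.09 log units; within the scatter) and a 1.5-fold higher number from compound 2 to compound 3 (0.17 log units; within the scatter) each exchange the whole group on the aromatic carbon and none moves the number beyond the scatter, so varied groups there have so far been tolerated. The step expected from the present change is therefore a 1.2-fold higher number from compound 1 to compound 4 (0.07 log units; within the scatter), with no direction beyond the scatter. Compound 4 is estimated at 20 nM, with a range from 8 nM to 50 nM.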

Compound 4, half-maximal inhibitory concentration: 17.9 nM
Compound 4: middle estimate off by 1.1-fold (0.05 log units), on the high side; the range from low to high includes it.
By their numbers in this assay, from the lowest: compounds 2, 1, 4 and 3 (each within the scatter of the next).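

In this assay, among the compounds shown here, the step of a 1.1-fold higher number from compound 1 to compound 4 (0.02 log units; within the scatter) is the first to vary only the group on the amine nitrogen in a ring, with the six-membered non-aromatic ring with 2 nitrogen kept. At this position, a pyridin-2-yl, with its six-membered aromatic ring and hydrogen-bond acceptor, is tolerated in place of isopropyl, a small group without a ring. Nothing available explains this tolerance.

Open, as far as these compounds go, is whether a carboxylic acid or a longer chain on this nitrogen would also stay within the scatter of compound 1. Also open, from the compounds shown here alone, is how a bare hydrogen there would compare.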